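A few compounds are considered here, and "the series" means these few. Any claim that something is new, unique, unknown or untested is made for them only; others in the source may bear on it.

Among the compounds with values here, compound 2, with the structure `CC(=O)N1CCC[C@H](c2csc(-c3ccccc3NC(=O)c3ncc[nH]3)n2)C1`, stands lowest of the two compounds measured so far in an ADME assay on microsomes from liver (Rattus norvegicus) (on this read-out lower numbers stand for lower hepatic extraction and higher numbers for higher hepatic extraction), where compound 2 gives 0.67. Within the data shown here, its only measured neighbour is compound 1, the structure `CCS(=O)(=O)N1CCC[C@H](c2csc(-c3ccccc3NC(=O)c3ncc[nH]3)n2)C1`, and in this assay compound 1 gives 0.86. Among the measured compounds shown here, the single measured step between these two, a number 0.19 lower from compound 1 to compound 2 (beyond the scatter), is the only guide available for what follows.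

Compound 3, with the structure `COC(=O)N1CCC[C@H](c2csc(-c3ccccc3NC(=O)c3ncc[nH]3)n2)C1`, has not yet been measured. It differs from compound 2 by methoxy in place of methyl on a carbonyl carbon. This change sits on the same carbonyl carbon attached to the amide-type nitrogen in the ring where the acetyl of compound 2 replaced the ethylsulfonyl of compound 1, but it is a smaller exchange. Since that one step, from ethylsulfonyl to acetyl, gave a modest drop beyond the scatter, a swap of methyl for methoxy on the same carbonyl carbon is expected to move this assay less, and in no clear direction, with a number 0.040 lower from compound 2 to compound 3 (within the scatter) likely to stay within the scatter. The expected value for compound 3 is therefore 0.63, with a plausible range from 0.5 to 0.76.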

Compound 3, hepatic extraction ratio: 0.69
Estimate against measurement, compound 3: 0.060 below; the measured number falls inside the stated range.
By their numbers in this assay, from the lowest: compounds 2 and 3 (each within the scatter of the next); then compound 1.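

In this assay, exchanging methyl for methoxy on a carbonyl carbon whose other neighbour is the amide-type nitrogen in a ring gives a number 0.020 higher from compound 2 to compound 3 (within the scatter), so the two compounds cannot be told apart on this read-out. The extra oxygen of the methoxy therefore leaves the result within the usual scatter, which a single step from ethylsulfonyl to acetyl could not show. The other new comparison gives a number 0.17 lower from compound 1 to compound 3 (beyond the scatter), and so, among these three compounds, both groups joined through a carbonyl carbon, acetyl and methoxycarbonyl, stand apart from ethylsulfonyl, with no compound here going against that.

Three compounds cannot show how far this holds, for instance whether a longer chain such as ethoxy or an amine such as dimethylamino on the same carbonyl carbon would also stay within the scatter of compound 2, or whether a smaller sulfonyl group such as methylsulfonyl would stand nearer to compound 1 or to compound 3. Nothing available explains why ethylsulfonyl differs from the two carbonyl groups on this read-out.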